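Removing both chlorines from a chalcone-type series

The compounds below may be only part of what the source reports. "The series", "measured", "known", "first", "only" and "open" are said of these compounds alone.

The three compounds that have been measured share a common core, seen in compound 1 `CNC(=O)c1cc(Oc2ccc(/C=C/C(=O)c3ccc([N+](=O)[O-])cc3)cc2)ccn1`, compound 2 `CNC(=O)c1cc(Oc2ccc(C(=O)/C=C/c3cc(OC)c(OC)c(OC)c3)cc2)ccn1` and compound 3 `CNC(=O)c1cc(Oc2ccc(C(=O)/C=C/c3ccc(Cl)cc3Cl)cc2)ccn1`. In a functional assay on MCF7 cells (Homo sapiens) for cytotoxicity, read by MTT assay, with a stated time of 72 h (on this read-out higher numbers stand for weaker inhibition and lower numbers for stronger inhibition), compound 1 gives 54300 nM, compound 2 gives 3880 nM and compound 3 gives 3990 nM. Compound 3 thus sits second highest of the three numbers, within the scatter of compound 2 and well apart from compound 1. Compound 4 `CNC(=O)c1cc(Oc2ccc(C(=O)/C=C/c3ccccc3)cc2)ccn1` has not yet been tested in this assay; it differs from compound 3 by phenyl in place of 2,4-dichlorophenyl on a double-bonded chain carbon bound to a double-bonded chain carbon. Without a measured step of this kind, only a modest rise, possibly within the scatter, is expected from compound 3 to compound 4 (a 2.0-fold higher number from compound 3 to compound 4 (0.30 log units; within the scatter)). Compound 4 is therefore estimated at 8000 nM, with a range of 2500 nM to 30000 nM.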

Compound 4, half-maximal inhibitory concentration: 5960 nM
The estimate for compound 4 lay 1.3-fold (0.13 log units) above the measured number; the measured number falls inside the stated range.
By their numbers in this assay, from the lowest: compounds 2, 3 and 4 (each within the scatter of the next); then compound 1.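

In this assay, within the data shown here, replacing 2,4-dichlorophenyl with phenyl on a double-bonded chain carbon bound to a double-bonded chain carbon gives a 1.5-fold higher number from compound 3 to compound 4 (0.17 log units; within the scatter), the first single-place change that can be read. At this position, then, losing both chlorines leaves the number within the scatter. No available evidence bears on this result.

Still open, on these data alone, is whether a phenyl carrying an amine or a carboxylic acid at this position would move the number beyond the scatter.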